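This account rests on a few compounds, and the source may have more. Where it says the series, first, only, none or still open, it means among the compounds named here.

In an assay on isolated protein (kidney, strain Wistar) for displacement of a labelled ligand from Translocator protein (Rattus norvegicus), read by scintillation counting, with a stated time of 90 min (on this read-out lower numbers stand for stronger inhibition and higher numbers for weaker inhibition), the measured compounds stand as follows:
compound 1, `CCN(CC)C(=O)Cc1c(-c2ccc(OCC3CCCCC3)cc2)nn2c(C)cc(C)nc12`, gives 3.6 nM;
compound 2, `CCN(CC)C(=O)Cc1c(-c2ccc(OCc3ccccc3F)cc2)nn2c(C)cc(C)nc12`, gives 0.31 nM;
compound 3, `CCN(CC)C(=O)Cc1c(-c2ccc(OCc3cccc(F)c3)cc2)nn2c(C)cc(C)nc12`, gives 0.47 nM.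

Compound 3 has the second highest of these three numbers: the step of a 1.5-fold higher number from compound 2 to compound 3 (0.18 log units; within the scatter) lies within the scatter, while the step of a 7.7-fold lower number from compound 1 to compound 3 (0.88 log units; beyond the scatter) lies beyond it. Compound 4, `CCN(CC)C(=O)Cc1c(-c2ccc(OCc3ccccc3C(F)(F)F)cc2)nn2c(C)cc(C)nc12`, differs from compound 3 in one place: 2-(trifluoromethyl)phenyl in place of 3-fluorophenyl on a saturated chain carbon bound to an oxygen on an aromatic ring. Among the compounds with values here, two measured steps bear on this position, a 12-fold lower number from compound 1 to compound 2 (1.06 log units; beyond the scatter) and a 7.7-fold lower number from compound 1 to compound 3 (0.88 log units; beyond the scatter), both large; the step of a 1.5-fold higher number from compound 2 to compound 3 (0.18 log units; within the scatter) shows that moving the fluorine gave no change beyond the scatter. Within the data shown here, no measured step covers a trifluoromethyl here, so compound 4 is expected to stay near compound 3, with an estimated step of a 1.1-fold higher number from compound 3 to compound 4 (0.03 log units; within the scatter). For compound 4 the estimate is 0.5 nM, between 0.15 nM and 2 nM.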

Compound 4, inhibition constant: 1.4 nM
Estimate against measurement, compound 4: 2.8-fold (0.45 log units) below; the range from low to high includes it.
By their numbers in this assay, from the lowest: compounds 2 and 3 (each within the scatter of the next); then compound 4; then compound 1.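

In this assay the group on this saturated chain carbon proved sensitive to a change on the aromatic ring: a 3.0-fold higher number from compound 3 to compound 4 (0.47 log units; beyond the scatter) and a 4.5-fold higher number from compound 2 to compound 4 (0.65 log units; beyond the scatter) both lie beyond the scatter, which moving the fluorine alone had not done. The aromatic group still held an edge over cyclohexyl, with a 2.6-fold lower number from compound 1 to compound 4 (0.41 log units; beyond the scatter) also beyond the scatter. No evidence is available to explain these steps.

Going by these compounds, how a chloro or methoxy group in place of fluoro on an aromatic carbon would read remains open.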